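The source may report more compounds than this note shows. Statements on the series, on what has been measured and on what is new or still open speak of the compounds shown alone.

Measured compounds:
Compound 1, `CCc1cc2ccccc2nc1-c1cc(-c2ccc(F)cc2)no1`, gives only a limit of the assay in a functional assay on PC-3 cells (Homo sapiens) for inhibition, read by MTT assay, with a stated time of 24 h (a higher number here means a weaker inhibitor, a lower number a stronger inhibitor), namely > 100000 nM.
Compound 2, `CCCc1cc2ccccc2nc1-c1cc(-c2ccc(F)cc2)no1`, gives in this assay a value of 42200 nM.
Compound 3, `CCCc1cc2ccccc2nc1-c1cc(-c2ccc(C)cc2)no1`, likewise gives only a limit in this assay, > 100000 nM.

The change from compound 1 to compound 2 is methyl in place of hydrogen on a saturated chain carbon, two bonds along the chain from an aromatic carbon, and it made an at least 2.3-fold lower number from compound 1 to compound 2 (0.37 log units; beyond the scatter). The next step was an at least 2.3-fold higher number from compound 2 to compound 3 (0.37 log units; beyond the scatter), and compound 3 stands at the limit of > 100000 nM in this assay, at which 2 of the 3 values shown sit. Compound 4, `CCCCc1cc2ccccc2nc1-c1cc(-c2ccc(C)cc2)no1`, has not been measured in this assay. It differs from compound 3 by methyl in place of hydrogen on a saturated chain carbon, three bonds along the chain from an aromatic carbon, the same kind of change as that from compound 1 to compound 2, though here the place is three bonds along the chain from an aromatic carbon rather than two. How the core of compound 3 differs from that of compound 1 is not broken down here. Resting on the step from compound 1 to compound 2, an at least 2.3-fold lower number from compound 1 to compound 2 (0.37 log units; beyond the scatter), a step of about that size is expected, an at least 1.4-fold lower number from compound 3 to compound 4 (0.15 log units; that floor lies within the scatter). Compound 4 is therefore estimated at 70000 nM, most likely between 25000 nM and 200000 nM, with a real chance that the assay again reports only a limit.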

Compound 4, half-maximal inhibitory concentration: > 100000 nM
Compound 4: no number, only a limit; the forecaster's own chance of this, stated with the estimate: 45%; at least 1.4-fold (0.15 log units) between middle value and limit.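

Compound 3 and compound 4 both give only a limit in this assay, so the step between them cannot be read: the limit of > 100000 nM in this assay, at which 3 of the 4 values shown sit.

Going by these compounds, whether propyl to butyl changes inhibition remains open, as does how far either compound lies past the limit.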